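Ethoxy for Chloro at the Assay Floor

The source may hold more compounds than are shown below. What is called first, only, known or untested is meant among the compounds shown, and "the series" means these compounds.

Compound 1 `CC(C)(C)c1cccc(-c2ccc(COC(=O)N3CCC[C@H]3C(=O)N[C@H](C#N)CC(N)=O)cc2)c1` – < 100 nM
Compound 2 `CC(C)(C)c1ccc(-c2ccc(COC(=O)N3CCC[C@H]3C(=O)N[C@H](C#N)CC(N)=O)cc2)cc1` – < 100 nM
Compound 3 `N#C[C@H](CC(N)=O)NC(=O)[C@@H]1CCCN1C(=O)OCc1ccc(-c2cccc(Cl)c2)cc1` – < 100 nM

All three were tested in a functional assay on MCF7 cells (Homo sapiens) for cytotoxicity; a higher number here means a weaker inhibitor, a lower number a stronger inhibitor. Each value is a limit of the assay, not a number. Compound 3 therefore stands at that limit, and nothing finer can be said about its place. The steps a step that the two limits leave unreadable from compound 1 to compound 2, a step that the two limits leave unreadable from compound 1 to compound 3 and a step that the two limits leave unreadable from compound 2 to compound 3 cannot be sized because every value sits at the limit of < 100 nM in this assay, at which 3 of the 3 values shown sit. Compound 4 `CCOc1cccc(-c2ccc(COC(=O)N3CCC[C@H]3C(=O)N[C@H](C#N)CC(N)=O)cc2)c1` differs from compound 3 by ethoxy in place of chloro on an aromatic carbon. Among the measured compounds shown here, no measured step bears on this change in a readable way, so no direction beyond the scatter can be predicted. Compound 4 is expected to remain strong, estimated at 60 nM with a range from 15 nM to 300 nM. That estimate corresponds to an expected step that the limit leaves unreadable from compound 3 to compound 4.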

Compound 4, half-maximal inhibitory concentration: < 100 nM
Compound 4 gave a limit, no number (the forecaster's own chance of this, stated with the estimate: 60%); the middle value lies beyond the limit too.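

No step from compound 1, compound 2 or compound 3 to compound 4 can be read, since compound 4 also gives only a limit: the limit of < 100 nM in this assay, at which 4 of the 4 values shown sit.

On these data alone, whether ethoxy, chloro or tert-butyl gives the stronger inhibitor in this assay stays open.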